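A Charged Group Replaces Methoxy

The source may report more compounds than this note shows. Statements on the series, on what has been measured and on what is new or still open speak of the compounds shown alone.

Compound 2 `COc1ccc(Cn2cc(C[N+](C)(C)C)c3ccccc32)cc1` carries a methoxy group on a six-membered aromatic ring. In an assay on HEK293 cells for antagonist activity at Neuronal acetylcholine receptor; alpha4/beta2 (Homo sapiens), read by calcium flux (a lower number here means a stronger inhibitor, a higher number a weaker inhibitor), compound 2 gives 4400 nM. Within the data shown here, its only measured neighbour is compound 1 `C[N+](C)(C)Cc1cn(Cc2ccccc2)c2ccccc12`, which lacks the methoxy and in this assay gives 4200 nM. The step of a 1.0-fold higher number from compound 1 to compound 2 (0.02 log units; within the scatter) shows that adding the methoxy changed little; of the two numbers compound 2 has the higher one, but the gap is within the scatter, so neither compound can be called the stronger inhibitor.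

Compound 3 `C[N+](C)(C)Cc1cn(Cc2ccc([N+](C)(C)C)cc2)c2ccccc12` takes the next step: a group of 4 heavy atoms (3 carbon, 1 nitrogen; no ring) in place of a group of 2 heavy atoms (1 carbon, 1 oxygen; no ring), on an aromatic carbon. Among the measured compounds shown here, no measured step introduces a charged group, so the expectation rests only on the finding that the same position tolerated hydrogen and methoxy alike. The expected step is a 1.5-fold lower number from compound 2 to compound 3 (0.17 log units; within the scatter). The estimate for compound 3 is 3000 nM, with a range from 600 nM to 15000 nM.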

Compound 3, half-maximal inhibitory concentration: 20000 nM
For compound 3 the middle estimate is 6.7-fold (0.82 log units) below the measured one; the measured number lies above the stated range.
By their numbers in this assay, from the lowest: compounds 1 and 2 (each within the scatter of the next); then compound 3.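

This position is not indifferent to every group, even though hydrogen and methoxy could not be told apart on it. In this assay the group with net charge +1 gives a 4.5-fold higher number from compound 2 to compound 3 (0.66 log units; beyond the scatter) and, measured against hydrogen, a 4.8-fold higher number from compound 1 to compound 3 (0.68 log units; beyond the scatter) as well, which makes compound 3 the weakest inhibitor of the three, though only by a modest margin. The data offer no measured explanation for this loss of inhibition.

The entering group differs from methoxy in its heavy atoms, its hydrogen-bond acceptors and its net charge all at once, so the compounds shown cannot separate these changes. A tert-butyl group, which carries no charge, would test the uncharged case, while a carboxylic acid on the same aromatic carbon would show how a different ionisable group behaves there.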